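Three Sulfonamides at the Assay Limit, a Fourth Awaited

The compounds below may be only part of what the source reports. "The series", "measured", "known", "first", "only" and "open" are said of these compounds alone.

Compound 1 `COc1ccccc1S(=O)(=O)Nc1ccc2oc(-c3ccccc3)nc2c1`: > 100000 nM
Compound 2 `COc1ccccc1S(=O)(=O)Nc1ccc(-c2nc3ccccc3o2)cc1`: > 100000 nM
Compound 3 `CCc1ccc(S(=O)(=O)Nc2ccc3oc(-c4ccccc4)nc3c2)cc1`: > 100000 nM

In an assay on cells for inhibition of HSP60/HSP10 (Homo sapiens), with a stated time of 60 min (on this read-out lower numbers stand for stronger inhibition and higher numbers for weaker inhibition), compound 1 gives > 100000 nM, which is a limit of the assay and not a number. In this assay compound 2 gives > 100000 nM, also a limit. In this assay compound 3 gives > 100000 nM, again a limit. Compound 1 and compound 3 differ by one change, (4-ethylphenyl in place of 2-methoxyphenyl on a sulfonyl sulfur); the step that the two limits leave unreadable from compound 1 to compound 3 cannot be read, because the limit of > 100000 nM in this assay, at which 3 of the 3 values shown sit, leaves no number on either side. Compound 1 and compound 2 have the same atoms joined differently; the difference between the two cores is not broken down here.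

Compound 4 `CCc1ccc(S(=O)(=O)Nc2ccc(-c3nc4ccccc4o3)cc2)cc1` has not yet been measured in this assay. It differs from compound 2 by 4-ethylphenyl in place of 2-methoxyphenyl on a sulfonyl sulfur, the same change that turns compound 1 into compound 3. Going by the values given here, for compound 4 the step that the limit leaves unreadable from compound 2 to compound 4 is expected to be about flat, resting on the limit of > 100000 nM in this assay, at which 3 of the 3 values shown sit, where every value so far sits. The estimate for compound 4 is therefore 150000 nM, expected to fall between 50000 nM and 500000 nM, most likely reported again only as a limit.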

Compound 4, half-maximal inhibitory concentration: > 100000 nM
Compound 4 was reported as a limit (the forecaster's own chance of this, stated with the estimate: 85%); the middle value is on the limit's open side.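

No step can be read from compound 2 to compound 4, because both compounds are reported only as a limit and not as a number: the limit of > 100000 nM in this assay, at which 4 of the 4 values shown sit.

The compounds shown leave open whether 4-ethylphenyl in place of 2-methoxyphenyl, or the difference between the two cores, has any effect on inhibition in this assay.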